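Chain Lengthening in a Carbamate Series: Metabolic Stability

The compounds below may be only part of what the source reports. "The series", "measured", "known", "first", "only" and "open" are said of these compounds alone.

Measured compounds:
Compound 1, `CCCCCCCCNC(=O)Oc1ccc(Cl)cc1C(=O)Nc1ccc(Cl)cc1`, 64 h
Compound 2, `CCCCCCCCCNC(=O)Oc1ccc(Cl)cc1C(=O)Nc1ccc(Cl)cc1`, 64 h
Compound 3, `CCCCCCCNC(=O)Oc1ccc(Cl)cc1C(=O)Nc1ccc(Cl)c(Cl)c1`, 64 h

Of the compounds shown here, three have been read in an ADME assay for metabolic stability, read by HPLC, at pH 7; a lower number here means that the compound disappears faster, a higher number that the compound lasts longer. Compound 1 gives 64 h, compound 2 gives 64 h, and compound 3 gives 64 h, so the three stand level within the scatter. From compound 1 to compound 2 the change is methyl in place of hydrogen on a saturated chain carbon, eight bonds along the chain from an amide-type nitrogen, and the step is no change at the digits printed from compound 1 to compound 2 (within the scatter).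

Compound 4, `CCCCCCCCNC(=O)Oc1ccc(Cl)cc1C(=O)Nc1ccc(Cl)c(Cl)c1`, is not yet measured. It differs from compound 3 by methyl in place of hydrogen on a saturated chain carbon, seven bonds along the chain from an amide-type nitrogen. The difference between the core of compound 1 and the core of compound 3 is not broken down here. The change from compound 3 to compound 4 is the same kind of change as that from compound 1 to compound 2, not the same one: the entering methyl sits seven bonds along the chain from an amide-type nitrogen rather than eight.

Because the step of no change at the digits printed from compound 1 to compound 2 (within the scatter) shows no change, the step of no change at the digits printed from compound 3 to compound 4 (within the scatter) in this assay is expected to be of similar size. Compound 4 is therefore estimated at 64 h, expected to fall between 40 h and 100 h.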

Compound 4, half-life: 64 h
For compound 4 middle estimate and measured number coincide at the digits printed, within the range that was stated.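

In this assay, methyl in place of hydrogen on a saturated chain carbon, seven bonds along the chain from an amide-type nitrogen, gives no change at the digits printed from compound 3 to compound 4 (within the scatter), and chloro in place of hydrogen on an aromatic carbon gives no change at the digits printed from compound 1 to compound 4 (within the scatter). Set beside the earlier step, the chain change reads the same on both cores: the same change on two cores in this assay, no change at the digits printed (within the scatter) from compound 1 to compound 2 and no change at the digits printed (within the scatter) from compound 3 to compound 4, 1.0-fold (0.00 log units) apart, within the scatter of two such steps. For the compounds shown here, this shows that the change carries across these two cores with no visible difference, but it rests on only two pairs, the entering methyl sits at a different distance along the chain in each, and it does not show that the same would hold on any other core.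

The compounds shown leave open whether a much shorter chain, a branched chain, or a chain ending in an amine or a carboxylic acid would stay level with these four in this assay. They also leave open how a fluoro or methoxy group in place of the chloro would read.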